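The source may hold more compounds than are shown below. What is called first, only, known or untested is meant among the compounds shown, and "the series" means these compounds.

Of the compounds shown here, two have been measured in an assay on CHO cells for displacement of a labelled ligand from C-X-C chemokine receptor type 3 (Homo sapiens), with a stated time of 60 min; on this read-out higher numbers stand for weaker inhibition and lower numbers for stronger inhibition. Compound 1 `CCCN(Cc1ccc(OCCn2c(=O)ccn(C)c2=O)c(OC)c1)C(CC(=O)O)c1ccc2c(c1)CCO2` gives 154 nM, and compound 2 `COc1cc(CN(CC(C)C)C(CC(=O)O)c2ccc3c(c2)CCO3)ccc1OCCN1C(=O)CCC1=O` gives 41 nM. Of the two numbers, compound 2 has the lower one, and the gap to compound 1 lies beyond the usual scatter, so compound 2 is the stronger inhibitor of the pair; the two structures differ in more than one place, so nothing more is read from that gap.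

Compound 3 `COc1cc(CN(CC(C)C)C(CC(=O)O)c2ccc(Cl)c(F)c2)ccc1OCCN1C(=O)CCC1=O` is not yet measured. It differs from compound 2 by a group of 8 heavy atoms (6 carbon, 1 fluorine, 1 chlorine; one six-membered aromatic ring of carbon only) in place of a group of 9 heavy atoms (8 carbon, 1 oxygen; one five-membered non-aromatic ring with 1 hetero atom, one six-membered aromatic ring of carbon only), on a saturated chain carbon bound to an amine nitrogen and a saturated chain carbon. Within the data shown here, nothing among the measured compounds shows what this exchange does in this assay, so the expected change from compound 2 to compound 3 is small and its direction uncertain, a 1.5-fold higher number from compound 2 to compound 3 (0.17 log units; within the scatter), which is expected to stay within the scatter. Compound 3 is therefore estimated at 60 nM in this assay, with a likely range from 15 nM to 250 nM.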

Compound 3, half-maximal inhibitory concentration in the C-X-C chemokine receptor type 3 assay: 70 nM
Beside the measured number, compound 3's estimate is 1.2-fold (0.07 log units) below it; the range from low to high includes it.
By their numbers in the C-X-C chemokine receptor type 3 assay, from the lowest: compounds 2 and 3 (each within the scatter of the next); then compound 1.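

In the C-X-C chemokine receptor type 3 assay, where compound 2 gives 41 nM and compound 3 gives 70 nM, putting 4-chloro-3-fluorophenyl on the saturated chain carbon bound to an amine nitrogen and a saturated chain carbon gives a 1.7-fold higher number from compound 2 to compound 3 (0.23 log units; within the scatter), so at this place the five-membered non-aromatic ring with its oxygen can give way to chlorine and fluorine without a change beyond the scatter. In a physicochemical assay for solubility, at pH 1.1 (a higher number here means a more soluble compound, a lower number a less soluble compound), compound 2 gives 3000000 nM and compound 3 gives 3000000 nM, and the same exchange gives no change at the digits printed from compound 2 to compound 3 (within the scatter). Nothing available accounts for either result at the level of mechanism.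

The compounds shown leave open how a plain phenyl, a pyridine ring, or a phenyl ring carrying only the chlorine or only the fluorine would read at this place. They also leave open whether 4-chloro-3-fluorophenyl would give a similar step on the core of compound 1.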